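Swapping the aryl group on the amino nitrogen of a shared core

The compounds below may be only part of what the source reports. "The series", "measured", "known", "first", "only" and "open" are said of these compounds alone.

Measured compounds:
compound 1 `N#Cc1c(Nc2ccccc2Cl)nc(SCc2cn(Cc3ccccc3Cl)nn2)nc1-c1ccccc1`, 1950 nM
compound 2 `N#Cc1c(Nc2ccc(F)cc2)nc(SCc2cn(Cc3ccccc3Cl)nn2)nc1-c1ccccc1`, 19900 nM

Both compounds were tested in a functional assay on MCF7 cells (Homo sapiens) for inhibition, read by MTT assay, with a stated time of 72 h; a higher number here means a weaker inhibitor, a lower number a stronger inhibitor. Compound 2 has the highest number of the two; the nearest is compound 1, and the step of a 10-fold higher number from compound 1 to compound 2 (1.01 log units; beyond the scatter) was large and beyond the scatter. Compound 3 `Cc1ccccc1Nc1nc(SCc2cn(Cc3ccccc3Cl)nn2)nc(-c2ccccc2)c1C#N` is not yet measured. It differs from compound 2 by 2-methylphenyl in place of 4-fluorophenyl on a nitrogen on an aromatic ring. Among the compounds with values here, the only step that bears on this is the one from compound 1 to compound 2, where 4-fluorophenyl replacing 2-chlorophenyl raised the number sharply. Reversing toward a 2-substituted phenyl is therefore expected to lower the number, roughly back toward compound 1. Compound 3 is estimated at 3000 nM, between 1200 nM and 8000 nM, corresponding to an expected step of a 6.6-fold lower number from compound 2 to compound 3 (0.82 log units; beyond the scatter).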

Compound 3, half-maximal inhibitory concentration: 7950 nM
Compound 3: middle estimate off by 2.7-fold (0.42 log units), on the low side; the range from low to high includes it.
By their numbers in this assay, from the lowest: compound 1; then compound 3; then compound 2.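

In this assay 2-methylphenyl gives a 2.5-fold lower number from compound 2 to compound 3 (0.40 log units; beyond the scatter), so it recovers only part of the rise seen with 4-fluorophenyl. Methyl in place of chloro gives a 4.1-fold higher number from compound 1 to compound 3 (0.61 log units; beyond the scatter), which shows that, in these compounds, 2-methylphenyl does not match 2-chlorophenyl on this nitrogen and that the identity of the group on the phenyl ring matters. Nothing available here explains these differences. Still open, as far as these compounds go, is how unsubstituted phenyl, 2-fluorophenyl or 4-chlorophenyl would compare. Those groups would help separate the choice of atom from where it sits on the ring.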